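Swapping an Acetyl for a Butyl on the Aromatic Ring

The compounds below may be only part of what the source reports. "The series", "measured", "known", "first", "only" and "open" are said of these compounds alone.

Of the compounds shown here, three built on one shared core have been tested in a functional assay on MCF7 cells (Homo sapiens) for cytotoxicity, read by MTT assay, with a stated time of 72 h; a lower number here means a stronger inhibitor, a higher number a weaker inhibitor. Compound 1 `COc1ccc(NC(=O)CSC(=S)N[C@H]2CCOC2=O)cc1` carries a methoxy group on its aromatic ring, and its result is only a limit of the assay, > 128000 nM. Compound 2 `O=C(CSC(=S)N[C@H]1CCOC1=O)Nc1ccc(F)cc1` carries a fluoro group instead, and in this assay compound 2 gives 5830 nM. Compound 3 `CC(=O)c1ccc(NC(=O)CSC(=S)N[C@H]2CCOC2=O)cc1` carries an acetyl group, and its result is again a limit, > 128000 nM. The move an at least 21-fold lower number from compound 1 to compound 2 (1.34 log units; beyond the scatter) shows that the group on this ring matters greatly, and the move an at least 21-fold higher number from compound 2 to compound 3 (1.34 log units; beyond the scatter) shows acetyl to be far less favourable than fluoro. The move a step that the two limits leave unreadable from compound 1 to compound 3 cannot be sized, since both ends sit at the limit of > 128000 nM in this assay, at which 2 of the 3 values shown sit.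

Compound 4 `CCCCc1ccc(NC(=O)CSC(=S)N[C@H]2CCOC2=O)cc1` differs from compound 3 by butyl in place of acetyl on an aromatic carbon. Among the measured compounds shown here, no measured step swaps acetyl for butyl, so the direction is uncertain; compound 3 sits at a limit, leaving room only for a lower number or another limit. Compound 4 is expected to give 60000 nM, within a range from 15000 nM to 200000 nM. That expectation amounts to an at least 2.1-fold lower number from compound 3 to compound 4 (0.32 log units; beyond the scatter).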

Compound 4, half-maximal inhibitory concentration: 40200 nM
Beside the measured number, compound 4's estimate is 1.5-fold (0.17 log units) above it; the range from low to high includes it.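

Butyl gives this position a second measured number, and fluoro stays ahead of it, with a 6.9-fold higher number from compound 2 to compound 4 (0.84 log units; beyond the scatter) in this assay. Butyl also stands clear of the two results that are only limits, with an at least 3.1-fold lower number from compound 3 to compound 4 (0.50 log units; beyond the scatter) and an at least 3.1-fold lower number from compound 1 to compound 4 (0.50 log units; beyond the scatter). Among the four groups shown, the two that hold oxygen, methoxy and acetyl, give only limits, while the two without it, fluoro and butyl, give numbers, and no compound shown goes against this.

On these data alone, the true distance of compound 1 and compound 3 from the others stays unknown, and the step between those two cannot be read: the limit of > 128000 nM in this assay, at which 2 of the 4 values shown sit. Also open, as far as these compounds go, is whether a propyl group, a longer chain, a chloro group or an amine on this aromatic carbon would land nearer fluoro or nearer butyl.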